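Methylating the Amide Nitrogen of Compound 3

The compounds below may be only part of what the source reports. "The series", "measured", "known", "first", "only" and "open" are said of these compounds alone.

Measured in a functional assay on MDA-MB-231 cells (Homo sapiens), read by microscopy and transwell migration, with a stated time of 24 h; on this read-out higher numbers stand for weaker inhibition and lower numbers for stronger inhibition:
- Compound 1 `C=CCn1c(-c2ccc(C)cc2C)cs/c1=N\C(=O)c1ccccc1`: 456 nM
- Compound 2 `COc1ccc(C(=O)Nc2nc(-c3cc(OC)c(OC)c(OC)c3)cs2)cc1OC`: > 25000 nM (a limit, not a number)
- Compound 3 `COc1cc(C(=O)Nc2nc(-c3cc(OC)c(OC)c(OC)c3)cs2)cc(OC)c1OC`: 1030 nM

Only two of these results are exact numbers. Compound 3 has the higher one at 1030 nM, while compound 1 gives 456 nM, so compound 3 is the weaker of the two by a gap just beyond the usual scatter.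

Compound 4 `COc1cc(C(=O)N(C)c2nc(-c3cc(OC)c(OC)c(OC)c3)cs2)cc(OC)c1OC` has not yet been measured. It differs from compound 3 by a single change: methyl in place of hydrogen on an amide-type nitrogen.

The only measured step between two of these compounds is an at least 24-fold lower number from compound 2 to compound 3 (1.38 log units; beyond the scatter). That large step is a methoxy in place of hydrogen on an aromatic carbon, so it is a different kind of change. Going by the values given here, it shows only that one small change can matter greatly in this assay. Among the compounds with values here, no measured step replaces the amide hydrogen directly. However, compound 1 carries no amide hydrogen either and still gives 456 nM, which suggests that losing this hydrogen need not remove activity.

No clear shift in either direction is therefore expected, and the estimated step is a 1.3-fold lower number from compound 3 to compound 4 (0.11 log units; within the scatter). For compound 4 the estimated value is 800 nM, with an expected range from 100 nM to 6000 nM.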

Compound 4, half-maximal inhibitory concentration: 470 nM
Compound 4: middle estimate off by 1.7-fold (0.23 log units), on the high side; low and high end bracket the measured number.
By their numbers in this assay, from the lowest: compounds 1 and 4 (each within the scatter of the next); then compound 3. At a limit, above all of these: compound 2.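

In this assay, going by these compounds alone, putting a methyl in place of the hydrogen on the amide-type nitrogen gives a 2.2-fold lower number from compound 3 to compound 4 (0.34 log units; beyond the scatter), the first measured step at this position and a modest one. For the compounds shown, this means the amide hydrogen is not needed for activity on this read-out: compound 4 has lost it and still gives 470 nM, and the number moved towards stronger inhibition rather than weaker. Nothing measured here explains why this single added carbon shifts the number, so the step can be reported but not accounted for.

Hydrogen and methyl are the only groups seen on this nitrogen, so it remains open whether a longer chain such as propyl, or a chain ending in an amine or a carboxylic acid, would lower the number further, leave it alone or raise it. Also open, going by these compounds, is whether the same methyl would change the result for compound 2, whose > 25000 nM is a limit and not a number.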